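A few compounds are considered here, and "the series" means these few. Any claim that something is new, unique, unknown or untested is made for them only; others in the source may bear on it.

Measured compounds in a functional assay on MCF7 cells (Homo sapiens) for inhibition, read by sulforhodamine B assay, with a stated time of 48 h; a lower number here means a stronger inhibitor of growth, a higher number a weaker inhibitor of growth:
- compound 1 `COC(=O)c1sc2cc(-c3cccnc3)cnc2c1N`: > 112000 nM
- compound 2 `COC(=O)c1sc2cc(-c3ccc4ccccc4c3)cnc2c1N`: 50900 nM
- compound 3 `COC(=O)c1sc2cc(-c3ccc4c(ccn4C)c3)cnc2c1N`: 23000 nM

Compound 1 stands at the edge of the measured range. Its value in this assay is a limit of the assay and not a number, as noted in the limit of > 112000 nM in this assay, at which 1 of the 3 values shown sits. Compound 2 and compound 3 carry bicyclic aryl groups on the shared core and give measurable values; what the two of them show is that compound 3 sits at the lower of the two numbers, with the gap between them close to the usual scatter.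

The unmeasured compound 4 `COC(=O)c1sc2cc(-c3ccc(N)cc3)cnc2c1N` differs from compound 1 in one place: 4-aminophenyl in place of pyridin-3-yl on an aromatic carbon, in words 4-aminophenyl in place of pyridin-3-yl on an aromatic carbon. Among the measured compounds shown here, no step between measured compounds covers this change. Since compound 1 reports only a limit, the step can only be described as an expectation. The expected step of an at least 1.8-fold lower number from compound 1 to compound 4 (0.27 log units; that floor lies within the scatter) is a modest move to a measurable value, with a real chance that this assay again reports only a limit. Compound 4 is estimated at 60000 nM, with a range from 15000 nM to 150000 nM.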

Compound 4, concentration for 50% growth inhibition: 108000 nM
For compound 4 the middle estimate is 1.8-fold (0.26 log units) below the measured one; the measured number falls inside the stated range.
By their numbers in this assay, from the lowest: compound 3; then compound 2; then compound 4. At a limit, above all of these: compound 1.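

Compound 1 gives > 112000 nM in this assay, which is a limit of the assay and not a number. With 4-aminophenyl on this aromatic carbon, compound 4 gives a measurable 108000 nM, so this position can carry a single six-membered aromatic ring of carbon only and still return a number, but the result shows only an at least 1.0-fold lower number from compound 1 to compound 4 (0.01 log units; that floor lies within the scatter). The true size of the change from pyridin-3-yl to 4-aminophenyl stays unknown because one end of the step is not a number: the limit of > 112000 nM in this assay, at which 1 of the 4 values shown sits.

What the amine itself contributes stays open, as the compounds shown include no plain phenyl for comparison. Also open, as far as these compounds go, is how a hydroxyl or a carboxylic acid in place of the amine on that phenyl ring would read in this assay.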